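Working notes on compound 1 and the step to compound 4

The compounds below may be only part of what the source reports. "The series", "measured", "known", "first", "only" and "open" are said of these compounds alone.

Compound 1 `Nc1cc(N)c2nc(-c3ccccc3)c(Oc3ccc(Cl)c(Cl)c3)nc2c1` has been measured only in a functional assay on SF-268 cells (Homo sapiens) for inhibition, read by sulforhodamine B assay, with a stated time of 48 h (a lower number here means that less compound is tolerated, a higher number that more compound is tolerated), where compound 1 gives < 100000 nM, which is a limit of the assay and not a number. Two further members share the core. Compound 2 `CCOC(=O)[C@H](CCC(=O)O)NC(=O)c1ccc(CNc2nc3cc(N)cc(N)c3nc2-c2ccccc2)cc1` gives < 100000 nM in this assay, again a limit. Compound 3 `CCOC(=O)[C@H](CCC(=O)O)NC(=O)c1ccc(Oc2nc3cc(N)cc(N)c3nc2-c2ccccc2)cc1` gives < 100000 nM in this assay, also a limit. Among the measured compounds shown here, no step between measured compounds can be read, since every value shown sits at the same limit (the limit of < 100000 nM in this assay, at which 3 of the 3 values shown sit), and where compound 1 stands relative to compound 2 and compound 3 is not resolved by these numbers.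

Compound 4 `Nc1cc(N)c2nc(-c3ccccc3)c(NCc3ccc(F)cc3)nc2c1` is not yet measured. It differs from compound 1 by (4-fluorobenzyl)amino in place of 3,4-dichlorophenoxy on an aromatic carbon. With only limits to hand, no direction can be taken from the measured compounds for this assay; the expected step is a step that the limit leaves unreadable from compound 1 to compound 4, that is, none beyond the scatter as far as the present numbers allow a judgement. Compound 4 is estimated at 30000 nM, expected to fall between 5000 nM and 100000 nM, with a fair chance that this assay again reports only a limit.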

Compound 4, concentration lethal to 50% of the cells: 40700 nM
Beside the measured number, compound 4's estimate is 1.4-fold (0.13 log units) below it, and the stated range covers the measured number.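

No step from compound 1 to compound 4 can be read, because the value of compound 1 is a limit and not a number: the limit of < 100000 nM in this assay, at which 3 of the 4 values shown sit.

The compounds shown leave open whether (4-fluorobenzyl)amino in place of 3,4-dichlorophenoxy changes the result in this assay at all, and in which direction.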